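Trimming the Alanine Side Chain in a Trypsin-Inert Series

A few compounds are considered here, and "the series" means these few. Any claim that something is new, unique, unknown or untested is made for them only; others in the source may bear on it.

The measured compounds:
Compound 1, `C[C@@H](NC(=O)c1ccc(Cl)s1)C(=O)Nc1ccc(N2CCOCC2=O)cc1`, in an assay on isolated protein for inhibition of Trypsin (Homo sapiens) (on this read-out higher numbers stand for weaker inhibition and lower numbers for stronger inhibition), compound 1 gives > 10000 nM, a limit of the assay.
Compound 2, `CCC[C@@H](NC(=O)c1ccc(Cl)s1)C(=O)Nc1ccc(N2CCOCC2=O)c(C)c1`, in this assay compound 2 gives > 10000 nM, a limit of the assay.
Compound 3, `CC[C@@H](NC(=O)c1ccc(Cl)s1)C(=O)Nc1ccc(N2CCOCC2=O)c(C)c1`, in this assay compound 3 gives > 10000 nM, a limit of the assay.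

Compound 3 therefore stands only at a limit in this assay, with no number of its own; the same holds for each of the other two measured compounds, as summed up by the limit of > 10000 nM in this assay, at which 3 of the 3 values shown sit. Going by the values given here, the one step that can be traced, a step that the two limits leave unreadable from compound 2 to compound 3, runs between two limits and its size cannot be read.

Compound 4, `Cc1cc(NC(=O)[C@@H](C)NC(=O)c2ccc(Cl)s2)ccc1N1CCOCC1=O`, differs from compound 3 by hydrogen in place of methyl on a saturated chain carbon, two bonds along the chain from an amide-type nitrogen and a carbonyl carbon. Among the compounds with values here, the only measured step that bears on it is the step from compound 2 to compound 3, which was unreadable, so no direction or size beyond the scatter can be expected in this assay for this change. The expectation is that compound 4 will likewise be reported only at the limit of the assay.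

The estimate for compound 4 in this assay is 20000 nM, with a range from 8000 nM to 80000 nM, meaning an expected step that the limit leaves unreadable from compound 3 to compound 4.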

Compound 4, half-maximal inhibitory concentration: > 10000 nM
Compound 4 was reported as a limit (the forecaster's own chance of this, stated with the estimate: 90%); the middle value does not contradict the limit.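

In this assay compound 4 gives > 10000 nM, a limit of the assay. Its steps from compound 1, compound 2 and compound 3 all run between limits, so no new step can be read. The compounds shown leave open how strongly any of them inhibits the enzyme, and whether hydrogen in place of methyl changes that, with every value at one limit: the limit of > 10000 nM in this assay, at which 4 of the 4 values shown sit.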